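A few compounds are considered here, and "the series" means these few. Any claim that something is new, unique, unknown or untested is made for them only; others in the source may bear on it.

Of the compounds shown here, three sharing one core have been measured in an assay on microsomes from brain for inhibition of Fatty-acid amide hydrolase 1 (Rattus norvegicus), read by fluorescence and HPLC, with a stated time of 60 min; a higher number here means a weaker inhibitor, a lower number a stronger inhibitor. Compound 1 `CCCCCCCCc1ccc(OCC(=O)Cn2nnc(-c3ccccc3)n2)cc1` gives 24 nM. Compound 2 `CCCCCCCCc1ccc(OCC(=O)Cn2nnc(-c3cccc(C(=O)OC)c3)n2)cc1`, which carries a methoxycarbonyl on the phenyl ring, gives 34 nM, and the step of a 1.4-fold higher number from compound 1 to compound 2 (0.15 log units; within the scatter) lies within the scatter. Compound 3 `CCCCCCCCc1ccc(OCC(=O)Cn2nnc(-c3ccc(S(=O)(=O)N(C)C)cc3)n2)cc1` gives 590 nM, the highest of the three numbers; the steps of a 25-fold higher number from compound 1 to compound 3 (1.39 log units; beyond the scatter) and a 17-fold higher number from compound 2 to compound 3 (1.24 log units; beyond the scatter) are both large and beyond the scatter, so compound 3 is the weakest inhibitor among the three.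

Compound 4 `CCCCCCCCc1ccc(OCC(=O)Cn2nnc(C(=O)O)n2)cc1` takes a different direction. The change from compound 3 is carboxy in place of 4-(dimethylsulfamoyl)phenyl on an aromatic carbon. Going by the values given here, no measured step removes the phenyl ring altogether, so none of the three steps matches this change directly. Among the compounds with values here, the steps of a 25-fold higher number from compound 1 to compound 3 (1.39 log units; beyond the scatter) and a 17-fold higher number from compound 2 to compound 3 (1.24 log units; beyond the scatter) show only that the number varies widely with what sits on that phenyl ring, and the whole ring is now absent. The expectation for this assay therefore rests on little, and the uncertainty is wide. Compound 4 is estimated at 1500 nM, with a range from 200 nM to 10000 nM, which means an expected step of a 2.5-fold higher number from compound 3 to compound 4 (0.41 log units; beyond the scatter), a further loss rather than a recovery toward compound 1.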

Compound 4, half-maximal inhibitory concentration: 41 nM
Compound 4: the middle estimate sits 37-fold (1.56 log units) above what was measured; measured number outside the range, below it.
By their numbers in this assay, from the lowest: compounds 1, 2 and 4 (each within the scatter of the next); then compound 3.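

In this assay, the aromatic carbon of the five-membered aromatic ring with 4 nitrogen keeps numbers of the same order without any phenyl ring: carboxy in place of phenyl gives a 1.7-fold higher number from compound 1 to compound 4 (0.23 log units; within the scatter), and carboxy in place of 3-(methoxycarbonyl)phenyl gives a 1.2-fold higher number from compound 2 to compound 4 (0.08 log units; within the scatter), both within the scatter. The large step seen earlier therefore does not mean that this position reads every change as a loss: replacing 4-(dimethylsulfamoyl)phenyl with carboxy gives a 14-fold lower number from compound 3 to compound 4 (1.16 log units; beyond the scatter), which leaves compound 3 as the only one of the four apart from the rest, while a much smaller group serves as well here as phenyl and 3-(methoxycarbonyl)phenyl do. No outside measurement bears on this result, so what lies behind it stays unexplained.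

The compounds shown leave open whether the number of compound 4 depends on the free carboxylic acid or would hold for its methyl ester, a primary amide, or a plain hydrogen at the same carbon. They also leave open whether the sulfonamide alone accounts for compound 3, which a phenyl ring bearing a carboxylic acid or a methylsulfonyl group could begin to separate from the effect of the ring itself.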